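Swapping Methyl for Carboxy on the Core of Compound 1

This account rests on a few compounds, and the source may have more. Where it says the series, first, only, none or still open, it means among the compounds named here.

Of the compounds shown here, three that share one core have been tested in a functional assay on the whole organism (blood, strain albino) with Mus musculus as the target, with stated times of 6 days and 4 h, at a dose of 0.4 mmol/kg by the oral route; on this read-out lower numbers stand for less inhibition and higher numbers for more inhibition at the one dose given (going by the name of the read-out). Compound 1 `CCNC(=O)NS(=O)(=O)c1ccc(-n2nc(C)cc2C)cc1` gives < 1%, which is a limit of the assay and not a number. Compound 2 `Cc1cc(C)n(-c2ccc(S(=O)(=O)NC(=O)NC3CCCCC3)cc2)n1` gives 10% in this assay. Compound 3 `CCCNC(=S)NS(=O)(=O)c1ccc(-n2nc(C)cc2C)cc1` gives < 1%, again a limit of the assay. Compound 1 therefore stands at the floor of what has been seen, where (the limit of < 1% in this assay, at which 2 of the 3 values shown sit).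

Both measured steps change the group on the nitrogen side of the core: a number at least 9 percentage points higher from compound 1 to compound 2 (that floor lies within the scatter), and a step that the two limits leave unreadable from compound 1 to compound 3. Neither touches the ring where compound 4 differs.

Compound 4 `CCNC(=O)NS(=O)(=O)c1ccc(-n2nc(C(=O)O)cc2C)cc1` differs from compound 1 by carboxy in place of methyl on an aromatic carbon. Among the measured compounds shown here, no measured step bears on this position, so there is no ground for expecting movement in either direction. The expected step is a number at least 1 percentage points higher from compound 1 to compound 4 (that floor lies within the scatter), within the scatter. Compound 4 is estimated at 2%, with a range from 0% to 12%.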

Compound 4, a percentage reported as inhibition, in the whole organism at one dose (the size of the read-out at that dose, not a potency): 0%
Beside the measured number, compound 4's estimate is 2 percentage points above it; low and high end bracket the measured number.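

No step from compound 1 to compound 4 can be read, since the value of compound 1 is a limit of the assay and not a number: the limit of < 1% in this assay, at which 2 of the 4 values shown sit.

The compounds shown leave open whether carboxy in place of methyl on an aromatic carbon moves the inhibition in either direction.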